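Swapping methoxy for fluoro on a shared phenol ring

The source may report more compounds than this note shows. Statements on the series, on what has been measured and on what is new or still open speak of the compounds shown alone.

Compound 1 `COc1ccc(/C=C/C(=O)C(=Cc2ccc(O)c(OC)c2)C(=O)/C=C/c2ccc(OC)cc2OC)c(OC)c1` and compound 2 `COc1ccc(/C=C/C(=O)C(=Cc2ccc(O)c(F)c2)C(=O)/C=C/c2ccc(OC)cc2OC)c(OC)c1` share one core and differ in one place, (fluoro in place of methoxy on an aromatic carbon). In a functional assay on A549 cells (Homo sapiens) for antiproliferative activity, read by sulforhodamine B assay, with a stated time of 48 h (on this read-out lower numbers stand for stronger inhibition and higher numbers for weaker inhibition), compound 1 gives 590 nM, and compound 2 gives 2070 nM, so a 3.5-fold higher number from compound 1 to compound 2 (0.55 log units; beyond the scatter). Compound 3 `COc1cc(OC)c(/C=C/C(=O)C(=Cc2ccc(O)c(OC)c2)C(=O)/C=C/c2c(OC)cc(OC)cc2OC)c(OC)c1` carries a different core, and the difference between the two cores is not broken down here; in this assay compound 3 gives 580 nM, which sits within the scatter of compound 1. Compound 4 `COc1cc(OC)c(/C=C/C(=O)C(=Cc2ccc(O)c(F)c2)C(=O)/C=C/c2c(OC)cc(OC)cc2OC)c(OC)c1` differs from compound 3 by the same change, (fluoro in place of methoxy on an aromatic carbon), at the same place. The step from compound 3 to compound 4 in this assay is expected to resemble the earlier one, a 3.4-fold higher number from compound 3 to compound 4 (0.54 log units; beyond the scatter), because a 3.5-fold higher number from compound 1 to compound 2 (0.55 log units; beyond the scatter) on the other core. Compound 4 is therefore expected to give about 2000 nM, between 900 nM and 4500 nM.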

Compound 4, half-maximal inhibitory concentration: 1060 nM
Estimate against measurement, compound 4: 1.9-fold (0.28 log units) above; measured number inside the range.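

In this assay, putting fluoro in place of the methoxy of the 4-hydroxy-3-methoxyphenyl group on the second core gives a 1.8-fold higher number from compound 3 to compound 4 (0.26 log units; within the scatter). Set beside the same change on the first core, the two steps do not differ by more than the scatter of such steps allows, so the change behaves alike on both cores: the same change on two cores in this assay, a 3.5-fold higher number (0.55 log units; beyond the scatter) from compound 1 to compound 2 and a 1.8-fold higher number (0.26 log units; within the scatter) from compound 3 to compound 4, 1.9-fold (0.28 log units) apart, within the scatter of two such steps. This rests on one pair per core, and the second step alone cannot be told from scatter, so it does not show that the number rises on every core, nor why it moves.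

Open, going by these compounds, is how an amine or a longer chain such as ethoxy at that place would compare with methoxy and fluoro. Also open, on these data alone, is whether the two cores would still track each other with such groups.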